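Amide in place of ethyl on the amine of compound 3

The compounds below may be only part of what the source reports. "The series", "measured", "known", "first", "only" and "open" are said of these compounds alone.

Compounds measured so far:
compound 1, `CC(C)C[C@H](N)c1cc(C(F)(F)F)ccc1N1CCN(C(=O)CCc2cccs2)CC1`, 4600 nM
compound 2, `CC(C)C[C@H](N)c1cc(C(F)(F)F)ccc1N1CCN(C(=O)CCc2cn(C)c3ccccc23)CC1`, 3000 nM
compound 3, `CCN[C@H](c1cc(C(F)(F)F)ccc1N1CCN(C(=O)CCc2ccc(Cl)cc2Cl)CC1)C(C)CC`, 92 nM

In an assay on HEK293 cells for displacement of a labelled ligand from Melanocortin receptor 4 (Homo sapiens) (a higher number here means a weaker inhibitor, a lower number a stronger inhibitor), compound 3 gives the lowest number of the three; compound 2 lies beyond the scatter above it and compound 1 further still. Compound 3 differs from compound 1 and compound 2 in several places at once, so neither gap can be tied to one structural change. Among the compounds with values here, the only single-site step measured is a 1.5-fold lower number from compound 1 to compound 2 (0.19 log units; within the scatter), an exchange of the ring on a saturated chain carbon two bonds along the chain from a carbonyl carbon, which leaves the amine untouched.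

Compound 4, `CCC(C)[C@H](NC(=O)CN)c1cc(C(F)(F)F)ccc1N1CCN(C(=O)CCc2ccc(Cl)cc2Cl)CC1`, is unmeasured. It differs from compound 3 in one place: (aminomethyl)carbonyl in place of ethyl on an amine nitrogen. Within the data shown here, no measured pair touches this nitrogen, so the step has no precedent; the one step recorded concerns another part of the molecule and sat within the scatter. A moderate weakening is expected, held with wide uncertainty. Compound 4 is estimated at 300 nM in this assay, with a range from 60 nM to 1500 nM. This corresponds to an expected step of a 3.3-fold higher number from compound 3 to compound 4 (0.51 log units; beyond the scatter).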

Compound 4, inhibition constant: 18 nM
The estimate for compound 4 lay 17-fold (1.22 log units) above the measured number; measured number outside the range, below it.
By their numbers in this assay, from the lowest: compound 4; then compound 3; then compounds 2 and 1 (each within the scatter of the next).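

In this assay, putting (aminomethyl)carbonyl in place of ethyl on the amine nitrogen gives a 5.1-fold lower number from compound 3 to compound 4 (0.71 log units; beyond the scatter), the first measured change at this nitrogen and the only single-site step shown that lies beyond the scatter. The nitrogen therefore accepts a larger group than ethyl, with 4 heavy atoms against 2 and with a hydrogen-bond donor and acceptors that ethyl lacks, and the number still falls; this rests on one pair, with the 2,4-substituted aryl amide side of compound 3 held constant. No supporting measurement speaks to the origin of this step.

On these data alone, it remains open whether the carbonyl or the terminal amine accounts for the step: an acetyl group, which lacks that amine, and a 3-aminopropanoyl group, which has a longer chain, would separate the two. Also open, as far as these compounds go, is whether the same exchange carries over to the thiophen-2-yl and 1-methyl-1H-indol-3-yl side chains of compound 1 and compound 2, which differ from compound 4 in several places and cannot be compared with it directly.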